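The source may hold more compounds than are shown below. What is called first, only, known or untested is meant among the compounds shown, and "the series" means these compounds.

In an ADME assay on MT4 cells (Homo sapiens) for cytotoxicity, read by MTT assay, with a stated time of 5 days (on this read-out lower numbers stand for higher toxicity in this test and higher numbers for lower toxicity in this test), compound 1 (`COCCNc1cc(Oc2c(C)cc(/C=C/C#N)cc2C)nc(Nc2ccc(C#N)cc2)n1`) gives 3190 nM. For the measured compounds named here, compound 3 (`Cc1cc(/C=C/C#N)cc(C)c1Oc1cc(Cl)nc(Nc2ccc(C#N)cc2)n1`) gives 4310 nM, so these two sit together at the low end of the numbers so far, while compound 2 (`Cc1cc(/C=C/C#N)cc(C)c1Oc1cc(Nc2ccc(C#N)cc2)nc(NC2CC2)c1`) gives a clearly higher 24800 nM.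

The unmeasured compound 4 (`Cc1cc(/C=C/C#N)cc(C)c1Oc1cc(NC2CC2)nc(Nc2ccc(C#N)cc2)n1`) keeps the core of compound 1 and alters one group: cyclopropyl in place of 2-methoxyethyl on a nitrogen on an aromatic ring. In short, cyclopropyl takes the place of 2-methoxyethyl on a nitrogen on an aromatic ring.

Going by the values given here, only one measured step touches this place. Replacing the whole (2-methoxyethyl)amino with chloro gave a 1.4-fold higher number from compound 1 to compound 3 (0.13 log units; within the scatter), but that is a different replacement, so it is only a loose guide. Compound 2 also carries cyclopropylamino, though on a different core, and its 24800 nM gives a weak hint upward.

A modest move toward a higher number is therefore expected, with an estimated 2.2-fold higher number from compound 1 to compound 4 (0.34 log units; beyond the scatter). For compound 4 the expected value is 7000 nM, with an estimated range of 2500 nM to 20000 nM.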

Compound 4, half-maximal cytotoxic concentration: 3000 nM
Beside the measured number, compound 4's estimate is 2.3-fold (0.37 log units) above it, within the range that was stated.
By their numbers in this assay, from the lowest: compounds 4, 1 and 3 (each within the scatter of the next); then compound 2.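

In this assay the swap gives a 1.1-fold lower number from compound 1 to compound 4 (0.03 log units; within the scatter) even though a chain with one hydrogen-bond acceptor leaves and a three-membered ring with none enters, so this place shows no readable response to that change. A second comparison, a 1.4-fold lower number from compound 3 to compound 4 (0.16 log units; within the scatter), also stays within the scatter, so chloro and cyclopropylamino on this aromatic carbon cannot be told apart here either. Compound 4 carries the same cyclopropylamino as compound 2, yet compound 4 gives 3000 nM and compound 2 gives 24800 nM, so that group alone does not go with the higher number.

From the compounds shown here alone, whether a free amine, a carboxylic acid or a longer alkyl chain at this place would also stay with these numbers remains open. The data offer no measured reason why these groups read alike.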